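The compounds below may be only part of what the source reports. "The series", "measured", "known", "first", "only" and "open" are said of these compounds alone.

Measured so far in an ADME assay on microsomes from liver (Mus musculus) for metabolic stability, read by LC-MS, with a stated time of 10 min, tested at 0.5 uM; a higher number here means that more of the compound is left, a lower number that less of the compound is left:
- compound 1 (`c1ccc2c(c1)CN[C@@H](CN(CCC1CCNCC1)[C@H]1CCCc3cccnc31)C2`): 32%
- compound 2 (`CCN1CCN(CCCN(C[C@H]2Cc3ccccc3CN2)[C@H]2CCCc3cccnc32)CC1`): 19%

Compound 2 has the lower of the two numbers, and compound 1 lies above it by more than the usual scatter. Compound 3 (`c1ccc2c(c1)CN[C@@H](CN(CCN1CCNCC1)[C@H]1CCCc3cccnc31)C2`) differs from compound 2 by one change (piperazin-1-yl in place of (4-ethylpiperazin-1-yl)methyl on a saturated chain carbon, two bonds along the chain from an amine nitrogen) in which piperazin-1-yl stands in place of (4-ethylpiperazin-1-yl)methyl on a saturated chain carbon, two bonds along the chain from an amine nitrogen. Among the compounds with values here, one measured step bears on this, the modest a number 13 percentage points lower from compound 1 to compound 2 (beyond the scatter) (beyond the scatter), where (4-ethylpiperazin-1-yl)methyl entered at that same place. From the compounds shown here alone, compound 3 loses this group, so a step of similar size in the opposite direction is expected, though a single step is thin evidence and piperazin-1-yl itself is untested. The expected step is a number 16 percentage points higher from compound 2 to compound 3 (beyond the scatter) in this assay by this estimate. Compound 3 is estimated at 35% with 18% to 58% as the expected range.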

Compound 3, percent of the compound remaining: 79%
Compound 3: the middle estimate sits 44 percentage points below what was measured, outside the stated range (above it).
By their numbers in this assay, from the lowest: compound 2; then compound 1; then compound 3.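

In this assay, piperazin-1-yl on a saturated chain carbon, two bonds along the chain from an amine nitrogen, gives a number 60 percentage points higher from compound 2 to compound 3 (beyond the scatter) when it replaces (4-ethylpiperazin-1-yl)methyl and a number 47 percentage points higher from compound 1 to compound 3 (beyond the scatter) when it replaces piperidin-4-yl. Compound 3 therefore stands highest of the three, so this position can shift the amount of compound left far more than the earlier pair showed. No measurement at hand explains this rise.

From the compounds shown here alone, compound 2 and compound 3 differ in both the ethyl group and the chain length, so the share of each in the step stays open. A 2-(4-ethylpiperazin-1-yl)ethyl or 3-(piperazin-1-yl)propyl group at this place would separate the two, while morpholin-4-yl would test whether the second ring nitrogen matters.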